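A few compounds are considered here, and "the series" means these few. Any claim that something is new, unique, unknown or untested is made for them only; others in the source may bear on it.

Working notes on the series. Compound 1 `CCn1ncc(-c2nc3c(N4CCC(n5c(=O)[nH]c6ncccc65)CC4)ncnc3n2C)c1C` and compound 2 `CCn1ncc(-c2nc3c(O[C@H]4CCN(C(=O)C5CC5)C4)ncnc3n2C)c1C` share the same core and have been measured in a physicochemical assay for lipophilicity; a higher number here means a more lipophilic compound, a lower number a more polar compound. In this assay compound 1 gives 1.4, and compound 2 gives 1.2. Compound 2 stands at the low end of the two numbers, but the value of compound 1 lies within the usual scatter of it, so the two cannot be told apart on these data.

Compound 3 `CCn1ncc(-c2nc3c(O[C@H]4CCN(C(=O)C5CCOCC5)C4)ncnc3n2C)c1C` has not yet been measured. It differs from compound 2 in one place: oxan-4-yl in place of cyclopropyl on a carbonyl carbon. Among the compounds with values here, no measured pair shows this change, so its size is not known from these data. The expected step in this assay from compound 2 to compound 3 is a number 0.30 log units lower from compound 2 to compound 3 (within the scatter), a modest shift toward the polar side. For compound 3 the estimate in this assay is 0.9, with a range from 0.5 to 1.3.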

Compound 3, distribution coefficient: 1.1
Estimate against measurement, compound 3: 0.20 log units below, and the stated range covers the measured number.
By their numbers in this assay, from the lowest: compounds 3, 2 and 1 (each within the scatter of the next).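

At this position, on a carbonyl carbon whose other neighbour is an amide-type nitrogen in a ring, the first measured change reads in this assay as a number 0.10 log units lower from compound 2 to compound 3 (within the scatter), so this pair cannot be told apart on this read-out. Oxan-4-yl brings 6 heavy atoms, including 1 oxygen, and 1 hydrogen-bond acceptor in place of the 3 carbon atoms and no acceptor of cyclopropyl, and this difference in the group does not produce a step beyond the scatter here. No measured information bears on the reason for this result.

The compounds shown leave open whether an amine, a carboxylic acid or a longer chain on the same carbonyl carbon would give a step beyond the scatter. With a single pair at this position, they also leave open whether the step from cyclopropyl to oxan-4-yl would read the same elsewhere in the series.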